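The source may report more compounds than this note shows. Statements on the series, on what has been measured and on what is new or still open speak of the compounds shown alone.

Measured so far in a functional assay on HT-29 cells (Homo sapiens) for cytotoxicity, read by MTT assay, with a stated time of 72 h; on this read-out lower numbers stand for stronger inhibition and higher numbers for weaker inhibition:
compound 1 `O=C(Nc1ccc(-n2ncc3c(C(F)(F)F)cccc32)cc1)Nc1ccc(Cl)c(C(F)(F)F)c1` gives 2900 nM
compound 2 `O=C(Nc1ccc(-n2ncc3ccccc32)cc1)Nc1ccc(Cl)c(C(F)(F)F)c1` gives 18200 nM
compound 3 `O=C(Nc1ccc(-n2ncc3c(C(F)(F)F)cccc32)cc1)Nc1ccc(C(F)(F)F)cc1` gives 3300 nM

Compound 3 stands second highest of the three numbers. Its nearest neighbour is compound 1, and that step a 1.1-fold higher number from compound 1 to compound 3 (0.06 log units; within the scatter) is within the scatter, so the two cannot be ordered on this assay. Against compound 2 the gap is beyond the scatter, and the two values show compound 2 as the weaker inhibitor of the pair.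

Compound 4 `O=C(Nc1ccc(-n2ncc3c(Cl)cccc32)cc1)Nc1ccc(C(F)(F)F)cc1` is the next step: chloro in place of trifluoromethyl on an aromatic carbon. Within the data shown here, the one measured step at this position of the fused system is a 6.3-fold higher number from compound 1 to compound 2 (0.80 log units; beyond the scatter), where the trifluoromethyl was removed outright. Here a chloro takes its place rather than nothing, so the change in this assay is expected to fall between no step and that modest loss. A small rise in the number is expected for compound 4, namely a 1.5-fold higher number from compound 3 to compound 4 (0.18 log units; within the scatter). Compound 4 is therefore estimated at 5000 nM in this assay. The expected range for compound 4 runs from 2000 nM to 13000 nM.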

Compound 4, half-maximal inhibitory concentration: 1000 nM
Compound 4: the middle estimate sits 5.0-fold (0.70 log units) above what was measured; measured number outside the range, below it.
By their numbers in this assay, from the lowest: compound 4; then compounds 1 and 3 (each within the scatter of the next); then compound 2.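

In this assay the trifluoromethyl on this aromatic carbon proves replaceable, as chloro in its place gives a 3.3-fold lower number from compound 3 to compound 4 (0.52 log units; beyond the scatter) and the number moves down rather than up. Among these compounds, until now the only change here was removal, with hydrogen in place of trifluoromethyl giving a 6.3-fold higher number from compound 1 to compound 2 (0.80 log units; beyond the scatter) on the 4-chloro-3-(trifluoromethyl)phenyl partner, so the series now shows that the outcome at this carbon depends on which group replaces trifluoromethyl. Nothing at hand speaks to what lies behind the chloro step.

On these data alone, it remains open whether a methyl, a methoxy or an amine on this carbon would give a number nearer that of chloro or that of hydrogen. As far as these compounds go, it is also open whether the chloro step carries over to the 4-chloro-3-(trifluoromethyl)phenyl partner on the amide-type nitrogen.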